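A few compounds are considered here, and "the series" means these few. Any claim that something is new, unique, unknown or untested is made for them only; others in the source may bear on it.

Of the compounds shown here, three sharing one core have been measured in a functional assay on MDA-MB-231 cells (Homo sapiens) for antiproliferative activity, read by CCK-8 assay, with a stated time of 72 h; a lower number here means a stronger inhibitor, a higher number a weaker inhibitor. Compound 1 (`Cc1cc(Nc2cc(N3CCN(C)CC3)nc(Nc3ccc(Cl)cc3)n2)n[nH]1`) gives 138 nM, compound 2 (`Cc1cc(Nc2cc(N3CCN(C)CC3)nc(Nc3cccc(Cl)c3)n2)n[nH]1`) gives 56.4 nM, and compound 3 (`Cc1cc(Nc2cc(N3CCN(C)CC3)nc(Nc3ccc(C#N)cc3)n2)n[nH]1`) gives 75.7 nM. Compound 3 holds the second highest of the three numbers, but its gaps to the other two lie within the scatter, as a 1.3-fold higher number from compound 2 to compound 3 (0.13 log units; within the scatter) shows on one side.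

Compound 4 (`COc1ccc(Nc2nc(Nc3cc(C)[nH]n3)cc(N3CCN(C)CC3)n2)cc1`) has not yet been measured. It differs from compound 3 by methoxy in place of cyano on an aromatic carbon, para to a large group. Among the compounds with values here, no measured compound carries a methoxy group, so the evidence is indirect. Within the data shown here, the nearest precedent is the exchange of chloro for cyano at this same place, a 1.8-fold lower number from compound 1 to compound 3 (0.26 log units; within the scatter), which stays within the scatter. Among the measured compounds shown here, the one step beyond the scatter, a 2.4-fold lower number from compound 1 to compound 2 (0.39 log units; beyond the scatter), is modest and moves the chlorine instead of exchanging the group, so it bears less on this change.

No step beyond the scatter is therefore expected in this assay, with only a slight lean towards the higher number of compound 1 at 138 nM. The expected move is a 1.3-fold higher number from compound 3 to compound 4 (0.12 log units; within the scatter). For compound 4 the estimate is 100 nM, with an expected range of 40 nM to 250 nM.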

Compound 4, half-maximal inhibitory concentration: 243 nM
The estimate for compound 4 lay 2.4-fold (0.39 log units) below the measured number; the measured number falls inside the stated range.
By their numbers in this assay, from the lowest: compounds 2, 3, 1 and 4 (each within the scatter of the next, the first and the last beyond it).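

The exchange at this place, on an aromatic carbon para to a large group, now gives a step beyond the scatter in this assay (a 3.2-fold higher number from compound 3 to compound 4 (0.51 log units; beyond the scatter)), which the earlier exchange of chloro for cyano on the same carbon did not. The gain from cyano is not shared by every group here, since 4-methoxyphenyl and 4-chlorophenyl stay within the scatter of each other (a 1.8-fold higher number from compound 1 to compound 4 (0.25 log units; within the scatter)), while compound 3 is separated from compound 4 but not from compound 1, so the three groups form no clean order. The 3-chlorophenyl group of compound 2 also stands clear of 4-methoxyphenyl, and this is the largest step among the four compounds (a 4.3-fold higher number from compound 2 to compound 4 (0.63 log units; beyond the scatter)), which widens the span of numbers that changes on this one aromatic ring can produce.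

No measurement offered here accounts for the difference between cyano and methoxy at this place. As far as these compounds go, whether an amine or a carboxylic acid on the same carbon would fall with cyano or with methoxy remains open, and so does whether a longer chain in place of methoxy would move the number further.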